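The compounds below may be only part of what the source reports. "The series", "measured", "known", "first", "only" and "open" are said of these compounds alone.

Working notes on the series in a functional assay on HCT-116 cells (Homo sapiens) for antiproliferative activity, read by MTT assay, with a stated time of 72 h; on this read-out higher numbers stand for weaker inhibition and lower numbers for stronger inhibition. Compound 1 (`COc1ccc(/C=C2/CN(C)/C(=N/c3ccc(C(C)(C)C)cc3)S2)cc1`) gives 25900 nM, compound 2 (`COc1ccc(/C=C2/CN(C)/C(=N/c3ccc(C)cc3)S2)cc1`) gives 11100 nM and compound 3 (`COc1ccc(/C=C2/CN(C)/C(=N/c3ccc(C(F)(F)F)cc3)S2)cc1`) gives 34300 nM. Compound 3 does not separate from compound 1, with a 1.3-fold higher number from compound 1 to compound 3 (0.12 log units; within the scatter). Compound 2 separates from both: a 2.3-fold lower number from compound 1 to compound 2 (0.37 log units; beyond the scatter) and a 3.1-fold higher number from compound 2 to compound 3 (0.49 log units; beyond the scatter).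

The open point is compound 4 (`COc1ccc(/C=C2/CN(C)/C(=N/c3ccc(Br)cc3)S2)cc1`). The change is bromo in place of trifluoromethyl on an aromatic carbon, para to a large group. All three measured steps swap a group on this same aromatic carbon, and none is larger than modest, so a large step is not expected here. Among the compounds with values here, no measured compound carries bromo, so these steps indicate a likely size but give only weak support for a direction. The working assumption is a value inside the span set by compound 2 and compound 3, which leaves only a lower number as possible from the present position. The expected change is a 1.6-fold lower number from compound 3 to compound 4 (0.21 log units; within the scatter), an estimated shift that should not clearly leave the scatter. The estimate for compound 4 is 21000 nM, with an expected range of 10000 nM to 40000 nM.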

Compound 4, half-maximal inhibitory concentration: 8900 nM
For compound 4 the middle estimate is 2.4-fold (0.37 log units) above the measured one; measured number outside the range, below it.
By their numbers in this assay, from the lowest: compounds 4 and 2 (each within the scatter of the next); then compounds 1 and 3 (each within the scatter of the next).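

In this assay, within the data shown here, bromo in place of trifluoromethyl on this aromatic carbon gives a step beyond the scatter, a 3.9-fold lower number from compound 3 to compound 4 (0.59 log units; beyond the scatter), and bromo in place of tert-butyl does the same, a 2.9-fold lower number from compound 1 to compound 4 (0.46 log units; beyond the scatter), so the carbon responds to a change of group in a way that the single step from compound 2 could not establish for any group but methyl. Bromo in place of methyl gives a 1.2-fold lower number from compound 2 to compound 4 (0.10 log units; within the scatter), which lies within the scatter, so compound 2 no longer stands alone: the four compounds now form two sets, compound 2 with compound 4 and compound 1 with compound 3, and the two groups of the first set cannot be ordered from these numbers. Nothing in hand explains why the groups divide in this way.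

Still open, on these data alone, is whether other halogens such as chloro or fluoro, or groups such as an amine, a hydroxyl or a nitrile, on this same aromatic carbon would join compound 2 and compound 4 or compound 1 and compound 3. As far as these compounds go, whether the same division holds with any change to the shared core also remains open.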